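Series notes: changing the chain-end group of compound 3

The source may report more compounds than this note shows. Statements on the series, on what has been measured and on what is new or still open speak of the compounds shown alone.

Measured in a functional assay on the whole organism with Rattus norvegicus as the target, at a dose of 100 mg/kg; on this read-out higher numbers stand for more inhibition at the one dose given (going by the name of the read-out) and lower numbers for less inhibition:
- compound 1, `CN(C)/C(=N/CCCCn1nc(-c2ccccc2)ccc1=O)NC#N`, gives 80.7%
- compound 2, `CC/N=C(\S)NCCCCCn1nc(-c2ccccc2)ccc1=O`, gives 66.4%
- compound 3, `C/N=C(\NC#N)NCCCCn1nc(-c2ccccc2)ccc1=O`, gives 79%

Compound 3 stands second of the three on these numbers, within the scatter of compound 1 and beyond it above compound 2. Compound 4, `CC(C)C/N=C(\S)NCCCCn1nc(-c2ccccc2)ccc1=O`, is not yet measured; it differs from compound 3 by a group of 7 heavy atoms (5 carbon, 1 nitrogen, 1 sulfur; no ring) in place of a group of 6 heavy atoms (3 carbon, 3 nitrogen; no ring), on an amine nitrogen.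

The group that enters compound 4 carries sulfur, as does the group of compound 2, and both the entering and the leaving group sit at the chain end. The two measured steps that bear on this are a number 12.6 percentage points higher from compound 2 to compound 3 (beyond the scatter) and a number 14.3 percentage points lower from compound 1 to compound 2 (beyond the scatter): in each, the sulfur-bearing group is the lower one by a modest amount. Compound 2 also differs from compound 4 elsewhere, so the comparison is not clean. A modest drop is therefore expected, a number 13 percentage points lower from compound 3 to compound 4 (beyond the scatter), and the inhibition of compound 4 is estimated at 66% with a range of 52% to 80%.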

Compound 4, a percentage reported as inhibition, in the whole organism at one dose (the size of the read-out at that dose, not a potency): 35.8%
Estimate against measurement, compound 4: 30.2 percentage points above, and the stated range ends above it.
By their numbers in this assay, from the lowest: compound 4; then compound 2; then compounds 3 and 1 (each within the scatter of the next).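

In this assay, for the compounds shown here, the sulfur-bearing group at this amine nitrogen gives a far larger loss than the earlier compounds showed, with a number 43.2 percentage points lower from compound 3 to compound 4 (beyond the scatter) and, likewise large, a number 44.9 percentage points lower from compound 1 to compound 4 (beyond the scatter). Sulfur alone does not set the level, since a number 30.6 percentage points lower from compound 2 to compound 4 (beyond the scatter) is also large and both of those groups carry sulfur, so the rest of the group matters at this place. No measurement at hand accounts for the loss.

As far as these compounds go, the step between the two sulfur-bearing compounds spans both the chain and the alkyl end of the group, so the part of that change behind the loss remains open. Also open, from the compounds shown here alone, is how a urea or a plain ethyl end on the chain of compound 4 would read out.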